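Second methoxy on the pendant ring of compound 3

The source may hold more compounds than are shown below. What is called first, only, known or untested is meant among the compounds shown, and "the series" means these compounds.

Measured so far in a functional assay on PC-3 cells (Homo sapiens) for cytotoxicity, read by sulforhodamine B assay; a lower number here means a stronger inhibitor, a higher number a weaker inhibitor:
compound 1, `Cc1ccc2c(N)nc(-c3c(C)cccc3C)cc2c1`, 240 nM
compound 2, `Cc1ccc2cc(-c3ccccc3C)nc(N)c2c1`, 260 nM
compound 3, `COc1cccc(-c2cc3cc(OC)c(OC)cc3c(N)n2)c1`, 180 nM

Compound 3 gives the lowest of the three numbers, but its distance to compound 1 and to compound 2 lies within the usual scatter, so the three compounds cannot be ranked against each other on these values.

Compound 4, `COc1cc(OC)cc(-c2cc3cc(OC)c(OC)cc3c(N)n2)c1`, has not been measured. It differs from compound 3 in one place: methoxy in place of hydrogen on an aromatic carbon. Within the data shown here, no pair of measured compounds that differ in a single place is available, so no measured step can be used to anchor an expectation. The change is small, a methoxy group added to a ring that already carries one, and none of the three measured compounds shows a wide spread despite differing in several places. For that reason the step from compound 3 to compound 4 is expected to stay within the scatter, a 1.1-fold higher number from compound 3 to compound 4 (0.05 log units; within the scatter), with no clear direction.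

Compound 4 is therefore estimated at 200 nM in this assay, with a range from 80 nM to 500 nM.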

Compound 4, half-maximal inhibitory concentration: 720 nM
Estimate against measurement, compound 4: 3.6-fold (0.56 log units) below; measured number above the stated range.
By their numbers in this assay, from the lowest: compounds 3, 1 and 2 (each within the scatter of the next); then compound 4.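

In this assay, methoxy in place of hydrogen on an aromatic carbon, meta to a methoxy group already on the ring, gives a 4.0-fold higher number from compound 3 to compound 4 (0.60 log units; beyond the scatter). Among these compounds, this is the first single-place change that can be read, and it shows that this position is sensitive: one added methoxy group moves the number beyond the scatter, towards a weaker inhibitor. Nothing available here accounts for this rise.

The compounds shown leave open whether a hydroxyl group, a fluorine atom or an ethoxy group on this same carbon would move the number as methoxy does. They also leave open whether the added methoxy group would give a step of this size on a ring without the first methoxy group.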